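A few compounds are considered here, and "the series" means these few. Any claim that something is new, unique, unknown or untested is made for them only; others in the source may bear on it.

Of the compounds shown here, two with a shared core have been measured in a functional assay on the whole organism (strain AKR) for inhibition, with Mus musculus as the target, read by paw edema, with a stated time of 3.5 h, at a dose of 0.01 mmol/kg by the intraperitoneal route; on this read-out higher numbers stand for more inhibition at the one dose given (going by the name of the read-out) and lower numbers for less inhibition. Compound 1 `O=C1N/C(=N\c2nccs2)S/C1=C\c1cccc(O)c1` gives 33.7% in this assay. Among the measured compounds shown here, compound 2 `Cc1ccc(/C=C2\S/C(=N/c3nccs3)NC2=O)cc1` gives 47% in this assay, the higher of the two numbers, and the only other number, that of compound 1, lies beyond the scatter below it. The account now turns to compound 3 `O=C1N/C(=N\c2nccs2)S/C1=C\c1ccc(Br)cc1`, which has not yet been measured in this assay. Its structure differs from that of compound 2 by one change: bromo in place of methyl on an aromatic carbon. For the measured compounds named here, no step between measured compounds covers a change at this place on the shared core, so the measured numbers give no guide to how this assay responds to it. The step is expected to be small, a number 2 percentage points lower from compound 2 to compound 3 (within the scatter), with no direction that goes beyond the scatter. Compound 3 is accordingly estimated at 45%, within a range from 28% to 60%.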

Compound 3, a percentage reported as inhibition, in the whole organism at one dose (the size of the read-out at that dose, not a potency): 42.2%
Beside the measured number, compound 3's estimate is 2.8 percentage points above it; the range from low to high includes it.
By their numbers in this assay, from the lowest: compounds 1, 3 and 2 (each within the scatter of the next, the first and the last beyond it).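

The step at this place now has a size: in this assay, bromo in place of methyl on an aromatic carbon, para to a large group, comes with a number 4.8 percentage points lower from compound 2 to compound 3 (within the scatter). On this read-out, at the one dose given, the two groups cannot be told apart, so this single exchange at this place does not move inhibition beyond what repeated measurements would show. Nothing available accounts for this outcome.

The compounds shown leave open how this assay would respond to a group of another kind at this place, such as an amine, a carboxylic acid or a longer chain. They also leave open whether methyl and bromo would remain indistinguishable at other doses, since each number here is the size of the read-out at a single dose and not a potency.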